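Moving One Fluorine on a Benzyl Group

The compounds below may be only part of what the source reports. "The series", "measured", "known", "first", "only" and "open" are said of these compounds alone.

Within the data shown here, in a functional assay on Bel-7402 cells (Homo sapiens) for antiproliferative activity, read by MTT assay, with a stated time of 72 h (a higher number here means a weaker inhibitor, a lower number a stronger inhibitor), compound 3 `C=C1C(=O)O[C@H]2[C@H]1CC/C(COC(=O)Cn1cc(F)c(=O)n(Cc3ccc(F)cc3)c1=O)=C\CC[C@@]1(C)O[C@@H]21` gives 2730 nM, the only true number measured so far. Compound 1 `C=C1C(=O)O[C@H]2[C@H]1CC/C(COC(=O)CCC(=O)N1CCN(C(=O)Cn3cc(F)c(=O)[nH]c3=O)CC1)=C\CC[C@@]1(C)O[C@@H]21` reads > 20000 nM, which is a limit of the assay and not a number. Compound 2 `C=C1C(=O)O[C@H]2[C@H]1CC/C(COC(=O)CCC(=O)N1CCN(C(=O)Cn3cc(F)c(=O)n(Cc4ccccc4)c3=O)CC1)=C\CC[C@@]1(C)O[C@@H]21` reads > 20000 nM, which is again a limit.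

Compound 4 `C=C1C(=O)O[C@H]2[C@H]1CC/C(COC(=O)Cn1cc(F)c(=O)n(Cc3ccccc3F)c1=O)=C\CC[C@@]1(C)O[C@@H]21` has the same atoms as compound 3, joined differently: 2-fluorophenyl stands in place of 4-fluorophenyl on a saturated chain carbon bound to an aromatic nitrogen, so 4-fluorobenzyl becomes 2-fluorobenzyl (2-fluorophenyl in place of 4-fluorophenyl on a saturated chain carbon bound to an aromatic nitrogen).

Among the measured compounds shown here, only one measured step exists to draw on, and it puts benzyl in place of hydrogen on an aromatic nitrogen: a step that the two limits leave unreadable from compound 1 to compound 2. It has no readable size because of the limit of > 20000 nM in this assay, at which 2 of the 3 values shown sit. It also says nothing about where a fluorine sits on a benzyl group, so the data offer no direction for this change. The best anchor is therefore compound 3 at 2730 nM, and a shift of one fluorine is not expected to carry the result beyond the usual scatter of this assay. The expected change is small: a 1.1-fold higher number from compound 3 to compound 4 (0.03 log units; within the scatter). Compound 4 is estimated at 2900 nM, with an expected range of 1200 nM to 7000 nM.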

Compound 4, half-maximal inhibitory concentration: 3770 nM
For compound 4 the middle estimate is 1.3-fold (0.11 log units) below the measured one, within the range that was stated.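

In this assay, among these compounds, moving the fluorine so that 4-fluorobenzyl becomes 2-fluorobenzyl gives the first step in this set with a readable size: a 1.4-fold higher number from compound 3 to compound 4 (0.14 log units; within the scatter). On this saturated chain carbon bound to an aromatic nitrogen, then, the two fluorophenyl groups cannot be told apart in this assay, and neither can be ranked above the other. The earlier step, benzyl in place of hydrogen on an aromatic nitrogen, could show nothing of this kind, and it remains unreadable because both of its values are limits and not numbers: the limit of > 20000 nM in this assay, at which 2 of the 4 values shown sit.

The compounds shown leave open whether the fluorine matters at all on this short link, since plain benzyl appears only on the longer chain of compound 2, and compound 2 differs from compound 3 in more than one place. They also leave open what a different group on the benzyl ring would do, such as a chlorine, a nitrile, an amine or a carboxylic acid in place of the fluorine.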